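Replacing a Carbonyl-Bearing Side Group with Bromo

The source may hold more compounds than are shown below. What is called first, only, known or untested is meant among the compounds shown, and "the series" means these compounds.

Measured in a functional assay on A549 cells (Homo sapiens) for cytotoxicity, with a stated time of 48 h; on this read-out lower numbers stand for stronger inhibition and higher numbers for weaker inhibition:
- Compound 1 `CCCCC(=O)Oc1ccc2oc(/C=C/[S+](C)[O-])cc(=O)c2c1`: 2400 nM
- Compound 2 `C[S+]([O-])/C=C/c1cc(=O)c2cc(OC(=O)C(C)(C)C)ccc2o1`: 1600 nM

Compound 2 stands within the usual scatter of compound 1, so the two cannot be ranked. Compound 3 `C[S+]([O-])/C=C/c1cc(=O)c2cc(Br)ccc2o1` alters compound 2 in one place: bromo in place of ((tert-butyl)carbonyl)oxy on an aromatic carbon. Among the measured compounds shown here, the only measured step, a 1.5-fold lower number from compound 1 to compound 2 (0.18 log units; within the scatter), exchanged butyl for tert-butyl on a carbonyl carbon. It kept the carbonyl that now leaves, so it is a weak guide. For the measured compounds named here, no step clearly beyond the scatter is expected in this assay, only a slight lean towards a higher number: a 1.9-fold higher number from compound 2 to compound 3 (0.27 log units; within the scatter) is the estimated step. For compound 3 the estimate is 3000 nM, with an expected range of 1000 nM to 9000 nM.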

Compound 3, half-maximal inhibitory concentration: 1100 nM
The estimate for compound 3 lay 2.7-fold (0.44 log units) above the measured number; the measured number falls inside the stated range.
By their numbers in this assay, from the lowest: compounds 3, 2 and 1 (each within the scatter of the next, the first and the last beyond it).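

At this aromatic carbon the carbonyl-bearing side group can be lost without a clear change in this assay: bromo in place of ((tert-butyl)carbonyl)oxy gives a 1.5-fold lower number from compound 2 to compound 3 (0.16 log units; within the scatter) for a much smaller group. Bromo in place of (butylcarbonyl)oxy gives a 2.2-fold lower number from compound 1 to compound 3 (0.34 log units; beyond the scatter), the first step in this set beyond the scatter, though only a modest one. Nothing measured here accounts for either step. Still open, from the compounds shown here alone, is how an amine, a carboxylic acid or a chloro group at this aromatic carbon would compare with bromo.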